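A few compounds are considered here, and "the series" means these few. Any claim that something is new, unique, unknown or untested is made for them only; others in the source may bear on it.

Compound 1 `C=C1C(=O)[C@@]23C(=O)OC[C@]4(C(=O)CCC(C)(C)[C@H]4C=O)[C@@H]2CC[C@@H]1[C@H]3O`: 5030 nM
Compound 2 `C=C1C(=O)[C@@]23C(=O)OC[C@]4(C(=O)CCC(C)(C)[C@H]4C=O)[C@@H]2CC[C@@H]1[C@H]3OC(=O)c1ccc(F)cc1`: 3750 nM

For the measured compounds named here, both compounds were tested in a functional assay on Bel-7402 cells (Homo sapiens) for cytotoxicity, read by MTT assay, with a stated time of 72 h (a lower number here means a stronger inhibitor, a higher number a weaker inhibitor), and compound 2 stands within the scatter of compound 1, the only other compound measured so far. Going by the values given here, the one measured step is a 1.3-fold lower number from compound 1 to compound 2 (0.13 log units; within the scatter), and it brings in the (4-fluorophenyl)carbonyl group.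

Compound 3 `C=C1C(=O)[C@@]23C(=O)OC[C@]4(C(=O)CCC(C)(C)[C@H]4C=O)[C@@H]2CC[C@@H]1[C@H]3OC(=O)c1ccccc1Cl` has not yet been measured. It carries 2-chlorophenyl in place of 4-fluorophenyl on a carbonyl carbon. Among the compounds with values here, no measured step changes this ring, so the data bear on the swap only indirectly. The closest guide is that the whole group came in with only a 1.3-fold lower number from compound 1 to compound 2 (0.13 log units; within the scatter). On that basis, no step beyond the scatter is expected in this assay, and compound 2, at 3750 nM, serves as the anchor for the expectation. The expected change is a 1.0-fold higher number from compound 2 to compound 3 (0.02 log units; within the scatter). For compound 3 the estimated value is 3900 nM, with an expected range from 1800 nM to 8000 nM.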

Compound 3, half-maximal inhibitory concentration: 2890 nM
For compound 3 the middle estimate is 1.3-fold (0.13 log units) above the measured one, within the range that was stated.
By their numbers in this assay, from the lowest: compounds 3, 2 and 1 (each within the scatter of the next).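

In this assay the exchange of 4-fluorophenyl for 2-chlorophenyl on the carbonyl carbon gives a 1.3-fold lower number from compound 2 to compound 3 (0.11 log units; within the scatter) and so does not separate the two rings, which have the same heavy-atom count and differ in their halogen and its place on the ring. Measured against the hydrogen on the oxygen of compound 1, the new (2-chlorophenyl)carbonyl group gives a 1.7-fold lower number from compound 1 to compound 3 (0.24 log units; within the scatter) and so, like the (4-fluorophenyl)carbonyl group before it, stays within the scatter, which means that two different aromatic acyl groups on this oxygen have now left the read-out indistinguishable from that of the parent. Nothing at hand explains why these numbers stay so close.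

Still open, going by these compounds, is whether this oxygen accepts other kinds of group equally well, for instance a phenyl ring bearing an amine or a carboxylic acid, or a longer alkyl chain in place of the ring, and whether any of these would produce a step beyond the scatter. The compounds shown also leave open whether the shared core responds to changes elsewhere, since every step so far falls on this one oxygen.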